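A few compounds are considered here, and "the series" means these few. Any claim that something is new, unique, unknown or untested is made for them only; others in the source may bear on it.

The series shares one core and varies the amino acid residue of the glycine-type ester. Compound 1 `O=C(CN(c1ncnc2c1ncn2C1CCCCO1)C1CC1)NCC(=O)OCc1ccccc1` carries hydrogen on the chain carbon bound to the amide-type nitrogen and the carbonyl carbon, compound 2 `O=C(CN(c1ncnc2c1ncn2C1CCCCO1)C1CC1)N[C@@H](CO)C(=O)OCc1ccccc1` carries hydroxymethyl there, and compound 3 `CC(C)C[C@H](NC(=O)CN(c1ncnc2c1ncn2C1CCCCO1)C1CC1)C(=O)OCc1ccccc1` carries isobutyl. In a functional assay on the whole organism (Tail, strain ICR) with Mus musculus as the target, in the tail flick test, with a stated time of 90 min, at a dose of 25 umol/kg by the oral route (on this read-out higher numbers stand for a stronger effect at the one dose given and lower numbers for a weaker effect), compound 1 gives 25.9%. In this assay compound 2 gives 32.2%. In this assay compound 3 gives 28.2%, which is the second highest of the three numbers; its nearest neighbour is compound 1 and its furthest is compound 2, and both gaps are within the scatter.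

Compound 4 `CC(C)[C@H](NC(=O)CN(c1ncnc2c1ncn2C1CCCCO1)C1CC1)C(=O)OCc1ccccc1` differs from compound 3 by one change: isopropyl in place of isobutyl on a saturated chain carbon bound to an amide-type nitrogen and a carbonyl carbon.

Within the data shown here, two measured steps bear on this. The step of a number 2.3 percentage points higher from compound 1 to compound 3 (within the scatter) shows that adding a branched alkyl at this chain carbon moved the number only within the scatter, and the step of a number 4 percentage points lower from compound 2 to compound 3 (within the scatter) shows a similarly small shift. Trimming isobutyl to isopropyl is a smaller change than either, so no step beyond the scatter in this assay is expected in either direction.

Compound 4 is therefore expected to give about 28% in this assay, within a range of 18% to 38%, a step of a number 0.2 percentage points lower from compound 3 to compound 4 (within the scatter) that is estimated to stay within the scatter.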

Compound 4, a percentage reported as activity, at one dose (the size of the read-out at that dose, not a potency): 30.1%
For compound 4 the middle estimate is 2.1 percentage points below the measured one; the measured number falls inside the stated range.
By their numbers in this assay, from the lowest: compounds 1, 3, 4 and 2 (each within the scatter of the next).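

With compound 4, isopropyl joins the groups seen on the saturated chain carbon bound to an amide-type nitrogen and a carbonyl carbon, and in this assay every new comparison stays inside the scatter: replacing isobutyl gives a number 1.9 percentage points higher from compound 3 to compound 4 (within the scatter), replacing hydroxymethyl gives a number 2.1 percentage points lower from compound 2 to compound 4 (within the scatter), and replacing hydrogen gives a number 4.2 percentage points higher from compound 1 to compound 4 (within the scatter). Hydrogen, hydroxymethyl, isobutyl and isopropyl at this carbon therefore cannot be told apart on this read-out at the one dose given, and shortening isobutyl to isopropyl leaves the number within the scatter. No evidence is available on why these four groups cannot be separated here.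

On these data alone, it remains open whether any group at this chain carbon can move the number beyond the scatter, for example a carboxylic acid or an amine carried on a longer chain. As far as these compounds go, with a single dose and a single time point, it also remains open whether these four compounds would separate at another dose or time in this assay.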